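A Pyridine in Place of Fluorophenyl on the Ether

The source may report more compounds than this note shows. Statements on the series, on what has been measured and on what is new or still open speak of the compounds shown alone.

Compound 2 `Cc1c(C2CC2)nc2ccc(-n3ccc(OCc4ccc(F)cc4)cc3=O)cn12` carries a cyclopropyl on an aromatic carbon and a (4-fluorobenzyl)oxy group. In an assay on CHO cells for displacement of a labelled ligand from melanin-concentrating hormone receptor 1 (Homo sapiens), read by scintillation counting, with a stated time of 1 h (a higher number here means a weaker inhibitor, a lower number a stronger inhibitor), compound 2 gives 47 nM, the higher of the two numbers recorded. Compound 1 `Cc1c(C2CC2)nc2ccc(NC(=O)COc3ccc(OC(F)(F)F)cc3)cn12`, with an amide-linked chain in place of the ring system bearing the ether, gives 3 nM in this assay. Compound 3 `Cc1c(CO)nc2ccc(-n3ccc(OCc4ccc(F)cc4)cc3=O)cn12` has hydroxymethyl in place of cyclopropyl on an aromatic carbon; in this assay compound 3 reaches only a limit, > 1000 nM. That is the limit of > 1000 nM in this assay, at which 1 of the 3 values shown sits. The step of an at least 21-fold higher number from compound 2 to compound 3 (1.32 log units; beyond the scatter) is thus known only as a bound.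

Compound 4 `Cc1c(C2CC2)nc2ccc(-n3ccc(OCc4cccnc4)cc3=O)cn12` differs from compound 2 elsewhere: pyridin-3-yl in place of 4-fluorophenyl on a saturated chain carbon bound to an oxygen on an aromatic ring. Among the compounds with values here, the single measured step touches the cyclopropyl side, not the benzylic ether, so nothing measured bears directly on this exchange. The step from compound 2 to compound 4 is therefore expected to stay within or close to the scatter, estimated as a 1.7-fold higher number from compound 2 to compound 4 (0.23 log units; within the scatter). Compound 4 is estimated at 80 nM in this assay, with a range from 25 nM to 300 nM.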

Compound 4, half-maximal inhibitory concentration: > 1000 nM
Compound 4: no number, only a limit; the forecaster's own chance of this, stated with the estimate: 5%; at least 12-fold (1.09 log units) between middle value and limit.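

The exchange of 4-fluorophenyl for pyridin-3-yl on a saturated chain carbon bound to an oxygen on an aromatic ring is no small change in this assay: it gives an at least 21-fold higher number from compound 2 to compound 4 (1.32 log units; beyond the scatter), so this side of the molecule, like the cyclopropyl side, can carry a large step. Going by these compounds, compound 4 reaches only a limit, > 1000 nM, and the true size of the step stays unknown. Each of the two single changes from compound 2 now ends at the same limit: the limit of > 1000 nM in this assay, at which 2 of the 4 values shown sit.

The compounds shown leave open whether the step follows from the ring nitrogen entering or from the fluorine leaving, as this one exchange does both at once. An unsubstituted phenyl or a 4-chlorophenyl on the same chain carbon would separate the two.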